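This account rests on a few compounds, and the source may have more. Where it says the series, first, only, none or still open, it means among the compounds named here.

Compound 1 `O=C(O)c1csc([C@H]2CC[C@@H]3[C@@H](COc4ccccc4F)[C@H](O)C[C@@H]3O2)n1` gives > 10000 nM in an assay on HEK293 cells for agonist activity at prostaglandin E2 receptor EP2 subtype (Homo sapiens), read by a beta-galactosidase reporter and beta-arrestin recruitment, with a stated time of 90 min (on this read-out higher numbers stand for an effect only at larger amounts of compound and lower numbers for an effect already at smaller amounts), a limit of the assay.
Compound 2 `O=C(O)c1csc([C@H]2CC[C@@H]3[C@@H](COc4cccc(F)c4)[C@H](O)C[C@@H]3O2)n1` gives > 10000 nM in this assay, again a limit.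
Compound 3 `O=C(O)c1csc([C@H]2CC[C@@H]3[C@@H](/C=C/CCOc4ccccc4)[C@H](O)C[C@@H]3O2)n1` gives > 10000 nM in this assay, again a limit.

Compound 1 therefore stands only at a limit, and the step that the two limits leave unreadable from compound 1 to compound 2 cannot be read. All three values sit at the limit of > 10000 nM in this assay, at which 3 of the 3 values shown sit. Compound 4 `O=C(O)c1csc([C@H]2CC[C@@H]3[C@@H](CCCOc4ccccc4)[C@H](O)C[C@@H]3O2)n1` differs from compound 1 by 2-phenoxyethyl in place of 2-fluorophenoxy on a saturated chain carbon bound to a saturated ring carbon. Going by the values given here, no measured step covers this change directly; compound 3, which also carries a phenoxy-bearing chain on the shared core, sits at the same limit. He therefore expects compound 4 to stay at the limit, with a step that the limit leaves unreadable from compound 1 to compound 4 expected to show no readable change. His estimate for compound 4 is 15000 nM, expected between 5000 nM and 60000 nM.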

Compound 4, half-maximal effective concentration: > 10000 nM
Compound 4 gave a limit, no number; the forecaster's own chance of this, stated with the estimate: 80%; the middle value lies beyond the limit too.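

In this assay, going by these compounds alone, compound 4 gives > 10000 nM, a limit, so no step from compound 1 or compound 2 to compound 4 can be read. The compounds shown leave open which change on the shared core would bring a measurable value: the limit of > 10000 nM in this assay, at which 4 of the 4 values shown sit.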